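Trimming the hydroxycarbamoyl chain of compound 2

This account rests on a few compounds, and the source may have more. Where it says the series, first, only, none or still open, it means among the compounds named here.

In an ADME assay on L02 cells (Homo sapiens) for cytotoxicity, read by MTT assay, with a stated time of 72 h (a lower number here means a stronger inhibitor, a higher number a weaker inhibitor), compound 2 (`C=CC(=O)Nc1cc2c(Nc3cccc(Cl)c3F)ncnc2cc1OCc1cn(CCCCC(=O)NO)nn1`) reads > 25000 nM and this is a limit, not a number. Compound 1 (`C=CC(=O)Nc1cc2c(Nc3ccc(F)c(Cl)c3)ncnc2cc1OCc1cn(CCC(=O)NO)nn1`) reads > 25000 nM and this too is a limit. Compound 3 (`C=CC(=O)Nc1cc2c(Nc3ccc(F)c(Cl)c3)ncnc2cc1OCc1cn(CCCCC(=O)NO)nn1`) reads > 25000 nM and this too is a limit.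

Compound 4 (`C=CC(=O)Nc1cc2c(Nc3cccc(Cl)c3F)ncnc2cc1OCc1cn(CCC(=O)NO)nn1`) is still unmeasured and differs from compound 2 in one place (hydroxycarbamoyl in place of 2-(hydroxycarbamoyl)ethyl on a saturated chain carbon, two bonds along the chain from an aromatic nitrogen): hydroxycarbamoyl in place of 2-(hydroxycarbamoyl)ethyl on a saturated chain carbon, two bonds along the chain from an aromatic nitrogen.

Within the data shown here, two measured steps bear on this: the same chain change run the other way (a step that the two limits leave unreadable from compound 1 to compound 3) and a change of the halogenated phenyl group (a step that the two limits leave unreadable from compound 2 to compound 3). Neither has a readable size, and the series offers only the limit of > 25000 nM in this assay, at which 3 of the 3 values shown sit, as its common ground. The chain of compound 4 is already carried by compound 1, which still reads > 25000 nM as a limit. The expected change in this assay is therefore none beyond the scatter, estimated as a step that the limit leaves unreadable from compound 2 to compound 4 in no clear direction.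

Expected for compound 4 is 30000 nM with an estimated range from 14000 nM to 70000 nM and probably only a limit reported.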

Compound 4, half-maximal inhibitory concentration: > 25000 nM
Compound 4: a limit, no number; the forecaster's own chance of this, stated with the estimate: 85%; the middle value lies beyond the limit too.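

In this assay compound 4 gives only a limit, so its steps from compound 2 and from compound 1 cannot be read, and it joins the rest of the series: the limit of > 25000 nM in this assay, at which 4 of the 4 values shown sit.

The compounds shown leave open how far past that limit each one lies, and whether changing the chain or the halogenated phenyl group makes any difference.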